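Solubility notes on the fused triazole series: compound 1 to compound 4

The source may hold more compounds than are shown below. What is called first, only, known or untested is meant among the compounds shown, and "the series" means these compounds.

Of the compounds shown here, three of the shared core have been measured in a physicochemical assay for solubility, at pH 6.5; on this read-out higher numbers stand for higher solubility and lower numbers for lower solubility. Compound 1 `COCc1nc2nc(C)cc(Nc3ccc(S(F)(F)(F)(F)F)cc3)n2n1` gives 63000 nM. Compound 3 `CCc1nc2nc(C)cc(Nc3ccc(C(F)(F)F)cc3)n2n1` gives 39000 nM, and the gap between compound 1 and compound 3 lies within the scatter of this assay, so no order between the two can be read from the numbers. Compound 2 `CCc1nc2nc(C)cc(Nc3cccc(Cl)c3)n2n1` gives 170000 nM, which sits beyond the scatter above compound 1; it is the only one of the three that stands clearly apart from compound 1.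

Among the compounds with values here, no pair of measured compounds differs in one place, so no single-point step is available from the measured set. The next compound, compound 4 `CSc1nc2nc(C)cc(Nc3ccc(S(F)(F)(F)(F)F)cc3)n2n1`, is to be measured in this assay. Relative to compound 1 it carries methylsulfanyl in place of methoxymethyl on an aromatic carbon.

Within the data shown here, since no measured pair isolates this kind of change, the expectation rests on compound 1 alone. The step of a 2.5-fold lower number from compound 1 to compound 4 (0.40 log units; beyond the scatter) is expected to be a modest decrease, somewhat beyond the scatter of this assay, though an outcome within the scatter would not be surprising. Compound 4 is therefore estimated at 25000 nM, with a range from 8000 nM to 80000 nM in this assay.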

Compound 4, solubility: 7800 nM
Compound 4: middle estimate off by 3.2-fold (0.51 log units), on the high side, and the stated range ends above it.
By their numbers in this assay, from the lowest: compound 4; then compounds 3 and 1 (each within the scatter of the next); then compound 2.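

In this assay the series now has its first single-point step, an 8.1-fold lower number from compound 1 to compound 4 (0.91 log units; beyond the scatter), and it shows that the aromatic carbon between two ring nitrogen atoms is a position where a change of substituent can move the read-out well beyond the scatter. This move comes with the shared core and the rest of compound 1 held constant, and the two groups match in the counted features: neither has a ring or a net charge, and they have the same numbers of hydrogen-bond donors and acceptors, so those counts alone do not separate them, while the heavy-atom count and the atoms themselves do differ. No measurement at hand bears on why the number drops, so the step stands as an observation only.

From the compounds shown here alone, it remains open whether the same step would appear with the aryl substituents of compound 2 and compound 3, since each of those carries ethyl at this position and neither forms a single-point pair with compound 1 or compound 4. Going by these compounds, how an amine, a carboxylic acid or a longer ether chain would stand at this carbon also remains open.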